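A few compounds are considered here, and "the series" means these few. Any claim that something is new, unique, unknown or untested is made for them only; others in the source may bear on it.

Compound 1: `COc1ccc(/C=C2\CCC/C(=C\c3cccc(OC)c3OC)C2=O)cc1OC` — 6400 nM
Compound 2: `COc1cccc(/C=C2\CCC/C(=C\c3ccc(OC)c(OC)c3)C2=O)c1` — 4600 nM

Among the measured compounds shown here, in a functional assay on HT-1080 cells (Homo sapiens) for cytotoxicity, read by MTT assay, with a stated time of 72 h (on this read-out higher numbers stand for weaker inhibition and lower numbers for stronger inhibition), compound 2 gives 4600 nM, the lowest of the two numbers so far. For the measured compounds named here, the only neighbour is compound 1 at 6400 nM, and the step of a 1.4-fold lower number from compound 1 to compound 2 (0.14 log units; within the scatter) is too small to count as a real difference. Compound 3 `COc1ccc(/C=C2\CCC/C(=C\c3ccc(O)c(O)c3)C2=O)cc1OC` alters the other ring: 3,4-dihydroxyphenyl in place of 3-methoxyphenyl on a double-bonded chain carbon bound to a double-bonded ring carbon. Going by the values given here, no measured step exchanges a methoxy group for hydroxy groups, so the one known step, which merely drops a methoxy, offers little guidance. The change is therefore expected to move the number little: a 1.2-fold lower number from compound 2 to compound 3 (0.06 log units; within the scatter). Compound 3 is estimated at 4000 nM, between 1500 nM and 12000 nM.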

Compound 3, half-maximal inhibitory concentration: 4200 nM
The estimate for compound 3 lay 1.1-fold (0.02 log units) below the measured number, and the stated range covers the measured number.
By their numbers in this assay, from the lowest: compounds 3, 2 and 1 (each within the scatter of the next).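

Placing 3,4-dihydroxyphenyl in place of 3-methoxyphenyl on a double-bonded chain carbon bound to a double-bonded ring carbon gives a 1.1-fold lower number from compound 2 to compound 3 (0.04 log units; within the scatter) in this assay. Among the compounds shown here, this is the first step here to add hydrogen-bond donors at this place, and it stays within the scatter, so this swap gives no real difference in this assay. Nothing available explains this result. On these data alone, whether a ring bearing an amine or a carboxylic acid at this place would read alike stays open, as does whether any group here can move the number beyond the scatter.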